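The source may hold more compounds than are shown below. What is called first, only, known or untested is meant among the compounds shown, and "the series" means these compounds.

Measured so far:
Compound 1 `CCOC(CCn1c(Cc2nn(C)c(=O)c3ccccc23)nnc1SCCCCCCCC(=O)Nc1ccc(Cl)cc1Cl)OCC`: > 30000 nM
Compound 2 `Cn1nc(Cc2nnc(SCCCCCCCC(=O)Nc3ccc(Cl)cc3Cl)n2CCCO[Si](C)(C)C(C)(C)C)c2ccccc2c1=O`: > 30000 nM

In an assay on NK92 cells for inhibition of interleukin-2 (Homo sapiens), read by AlphaScreen, with stated times of 30 min and 1 h (on this read-out lower numbers stand for stronger inhibition and higher numbers for weaker inhibition), compound 1 gives > 30000 nM, which is a limit of the assay rather than a measured number. Compound 2 in this assay gives > 30000 nM, again a limit and not a number. Among the measured compounds shown here, because both values sit at the same limit (the limit of > 30000 nM in this assay, at which 2 of the 2 values shown sit), the single step between the measured compounds, a step that the two limits leave unreadable from compound 1 to compound 2, cannot be read; its size and direction stay unknown. Compound 2 therefore stands at the limit, with nothing shown beneath it.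

Compound 3 `Cn1nc(Cc2nnc(SCCCCCCCC(=O)Nc3ccc(Cl)cc3Cl)n2CCCO)c2ccccc2c1=O` is the next compound to be measured in this assay. It differs from compound 2 in one place: a hydrogen atom in place of a group of 7 heavy atoms (6 carbon, 1 silicon; no ring), on an oxygen on a saturated carbon. The silicon-bearing group leaves and a bare hydroxyl remains on the saturated chain. For the measured compounds named here, no readable step among the measured compounds bears on this change, since the only step available is hidden by the limits. The expected step, a number no higher from compound 2 to compound 3 (the limit leaves the size open), is therefore set to none beyond the scatter. Compound 3 is expected to give about 30000 nM, within a range from 5000 nM to 100000 nM, most likely again reported only as a limit.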

Compound 3, half-maximal inhibitory concentration: > 30000 nM
Compound 3: only a limit was reported; the forecaster's own chance of this, stated with the estimate: 70%; the middle value lies on the limit itself.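

Among the compounds shown here, no step among compound 1, compound 2 and compound 3 can be read, because all three give a limit of the assay rather than a number: the limit of > 30000 nM in this assay, at which 3 of the 3 values shown sit.

The compounds shown leave open whether the groups on the saturated chain make any difference in this assay at all, and what measured number each compound would give.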